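From 3-fluorophenyl to 3-aminophenyl: an expected modest step

The source may report more compounds than this note shows. Statements on the series, on what has been measured and on what is new or still open speak of the compounds shown alone.

Three related compounds have been measured in a functional assay (aorta) for inhibition, with Rattus norvegicus as the target, with a stated time of 8 days (on this read-out lower numbers stand for stronger inhibition and higher numbers for weaker inhibition), so far. Compound 1 `Cc1nsc(-c2nccc(N3CCN(c4cccc(C(F)(F)F)c4)CC3)n2)n1` gives only a limit (> 100 nM). Compound 2 `CN(C)c1nsc(-c2ccc(N3CCN(c4cccc(C(F)(F)F)c4)CC3)nn2)n1` has two differing entries (6 nM; 0.4 nM (2 entries)). Among the measured compounds shown here, compound 3 `Cc1nsc(-c2ccc(N3CCN(c4cccc(F)c4)CC3)nn2)n1` gives 6 nM as the only single number of the three. Compound 4 `Cc1nsc(-c2ccc(N3CCN(c4cccc(N)c4)CC3)nn2)n1` differs from compound 3 in one place amino in place of fluoro on an aromatic carbon with amino in place of fluoro on an aromatic carbon. For the measured compounds named here, no measured pair shows this kind of change. A modest weakening is expected in this assay (a 2.0-fold higher number from compound 3 to compound 4 (0.30 log units; within the scatter)). The expected range stays wide because the several entries of compound 2 in this assay, 6 nM; 0.4 nM (2 entries) lie far apart. Compound 4 is estimated at 12 nM (expected range 2 nM to 80 nM).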

Compound 4, half-maximal inhibitory concentration: > 100 nM
Compound 4 was reported as a limit (the forecaster's own chance of this, stated with the estimate: 10%); at least 8.3-fold (0.92 log units) between middle value and limit.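

In this assay, among the compounds shown here, this position on the aromatic carbon proves sensitive: amino in place of fluoro gives an at least 16-fold higher number from compound 3 to compound 4 (1.22 log units; beyond the scatter), a large weakening that no earlier pair could show. A swap of one heavy atom for one heavy atom, which adds one hydrogen-bond donor and one acceptor, is therefore enough to produce a step beyond the scatter. On these data alone, its full size stays unknown because compound 4 is reported only as a limit: the limit of > 100 nM in this assay, at which 2 of the 4 values shown sit.

As far as these compounds go, whether the weakening is particular to amino remains open. A hydroxyl or methoxy group at this position could show whether strength like that of compound 3 can be kept.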